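Swapping trifluoromethyl for nitro on a benzyloxy anilinoquinazoline

This account rests on a few compounds, and the source may have more. Where it says the series, first, only, none or still open, it means among the compounds named here.

Four compounds share a quinazoline core bridged by a polyether ring, with an aniline bearing a substituted benzyloxy group. Compound 1 `O=[N+]([O-])c1ccc(COc2ccc(Nc3ncnc4cc5c(cc34)OCCOCCO5)cc2)cc1` carries a nitro group on the outer ring, compound 3 `FC(F)(F)c1ccc(COc2ccc(Nc3ncnc4cc5c(cc34)OCCOCCO5)cc2)cc1` a trifluoromethyl group in the same position, and compound 2 `FC(F)(F)c1ccc(COc2ccccc2Nc2ncnc3cc4c(cc23)OCCOCCOCCO4)cc1` a trifluoromethyl group with a differently shaped aniline and a larger polyether ring. The difference between the cores of compound 2 and compound 3 is not broken down here.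

In a functional assay on MCF7 cells (Homo sapiens) for antiproliferative activity, read by MTT assay, with a stated time of 72 h (a lower number here means a stronger inhibitor, a higher number a weaker inhibitor), compound 1 gives 39700 nM. Compound 3 reaches only the limit of this assay, > 100000 nM. Compound 2 likewise reaches only the limit, > 100000 nM. Going by the values given here, the one measured step is an at least 2.5-fold lower number from compound 3 to compound 1 (0.40 log units; beyond the scatter), the change being (nitro in place of trifluoromethyl on an aromatic carbon). It is worth noting (the limit of > 100000 nM in this assay, at which 2 of the 3 values shown sit), so the true size of that step is not known.

Compound 4 `O=[N+]([O-])c1ccc(COc2ccccc2Nc2ncnc3cc4c(cc23)OCCOCCOCCO4)cc1` has not yet been measured. It is related to compound 2 by exactly the same change, (nitro in place of trifluoromethyl on an aromatic carbon), with the same surroundings as in the step from compound 3 to compound 1. Compound 3 sits at the limit of this assay, > 100000 nM. Because compound 1 gives 39700 nM, a step of similar direction is expected from compound 2 to compound 4, estimated as an at least 2.0-fold lower number from compound 2 to compound 4 (0.30 log units; that floor lies within the scatter). Compound 4 is therefore expected to come in around 50000 nM, with a plausible range from 20000 nM to 120000 nM, and a real chance that this assay again reports only a limit.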

Compound 4, half-maximal inhibitory concentration: > 100000 nM
Compound 4 ended at the assay's limit (the forecaster's own chance of this, stated with the estimate: 40%); middle value at least 2.0-fold (0.30 log units) from the limit.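

In this assay compound 4 gives > 100000 nM, which is a limit of the assay and not a number. Compound 2 also sits at a limit, so no step between compound 2 and compound 4 can be read: the limit of > 100000 nM in this assay, at which 3 of the 4 values shown sit.

The compounds shown leave open whether nitro in place of trifluoromethyl makes any difference on the core shared by compound 2 and compound 4.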